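Chlorine in Place of Fluorine on the Aryl Group

The source may hold more compounds than are shown below. What is called first, only, known or untested is meant among the compounds shown, and "the series" means these compounds.

Compound 1, `Nc1scc(CN2CCN(c3cc(F)cc(F)c3)CC2)c1C(=O)c1ccc(Cl)cc1`, gives -13% in a functional assay on CHO cells with adenosine receptor A1 (Homo sapiens) as the target, read by cAMP accumulation and immunoassay, with a stated time of 6 min, tested at 0.01 uM; a lower number here means a stronger effect, a higher number a weaker effect of the compound at the concentration tested.
Compound 2, `Nc1scc(CN2CCN(c3cc(F)ccc3F)CC2)c1C(=O)c1ccc(Cl)cc1`, gives 3.1% in this assay.

Compound 2 stands highest of the two numbers shown, and its nearest neighbour is compound 1. For the measured compounds named here, the single measured step, a number 16.1 percentage points higher from compound 1 to compound 2 (beyond the scatter), came from putting 2,5-difluorophenyl in place of 3,5-difluorophenyl on an amine nitrogen in a ring, so it concerns where the halogens sit, not which halogen they are.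

Compound 3, `Nc1scc(CN2CCN(c3cc(Cl)ccc3Cl)CC2)c1C(=O)c1ccc(Cl)cc1`, differs from compound 2 by 2,5-dichlorophenyl in place of 2,5-difluorophenyl on an amine nitrogen in a ring. No measured step swaps fluorine for chlorine at unchanged positions, so nothing shown bears directly on this change. In this assay a step no larger than the usual scatter is expected in either direction, namely a number 0.1 percentage points lower from compound 2 to compound 3 (within the scatter). Compound 3 is therefore estimated at 3%, with a range from -12% to 18%.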

Compound 3, a percentage reported as activity, at one concentration (the size of the read-out at that concentration, not a potency): 13%
Compound 3: middle estimate off by 10 percentage points, on the low side, within the range that was stated.
By their numbers in this assay, from the lowest: compound 1; then compounds 2 and 3 (each within the scatter of the next).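

For the compounds shown here, exchanging the two fluorines of 2,5-difluorophenyl for chlorines gives the first direct comparison of the two halogens on this ring. In this assay, this change gives a number 9.9 percentage points higher from compound 2 to compound 3 (within the scatter), so the two groups cannot be told apart here. Replacing 3,5-difluorophenyl with 2,5-dichlorophenyl gives a number 26 percentage points higher from compound 1 to compound 3 (beyond the scatter), so both 2,5-substituted groups now stand apart from 3,5-difluorophenyl, whichever halogen they carry; no measurement shown explains this difference.

The compounds shown leave open whether the halogen would matter on 3,5-difluorophenyl, which a compound carrying chlorines in place of its two fluorines could test. They also leave open how a plain phenyl, or a phenyl bearing methyl or methoxy groups in place of the halogens, would read at this position.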